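This account rests on a few compounds, and the source may have more. Where it says the series, first, only, none or still open, it means among the compounds named here.

Compound 1 `CCCN(CCC)c1cc(C)nc2c(-c3ncc(N=O)cc3C)c(C)nn12` and compound 2 `CCCN(CCC)c1cc(C)nc2c(-c3ncc(F)cc3C)c(C)nn12` share one core and differ only on the pyridyl ring. In an assay on isolated protein for binding affinity to corticotropin-releasing factor receptor 1 (Homo sapiens) (on this read-out higher numbers stand for weaker inhibition and lower numbers for stronger inhibition), compound 1 gives 100 nM, and compound 2 gives 19 nM, the lowest of the two numbers; the step of a 5.3-fold lower number from compound 1 to compound 2 (0.72 log units; beyond the scatter) separates them. Compound 3 `CCCN(CCC)c1cc(C)nc2c(-c3ncc(O)cc3C)c(C)nn12` carries hydroxy in place of fluoro on an aromatic carbon. No measured step swaps a fluoro for a hydroxy group, and the only step shown tells that this position tolerates change; a hydroxy group is expected to cost some affinity, a 2.4-fold higher number from compound 2 to compound 3 (0.37 log units; beyond the scatter). Compound 3 is therefore estimated at 45 nM, within 12 nM to 170 nM.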

Compound 3, inhibition constant: 530 nM
Compound 3: the middle estimate sits 12-fold (1.07 log units) below what was measured; the whole stated range lies below it.
By their numbers in this assay, from the lowest: compound 2; then compound 1; then compound 3.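

In this assay, for the compounds shown here, the place para to a large group proves much less forgiving than the one earlier step suggested: hydroxy in place of fluoro brings a 28-fold higher number from compound 2 to compound 3 (1.45 log units; beyond the scatter). Hydroxy also ranks behind the nitroso group, with a 5.3-fold higher number from compound 1 to compound 3 (0.72 log units; beyond the scatter), so the order of the three groups at this place is now fixed. Nothing shown explains why hydroxy fares worst. As far as these compounds go, whether the hydrogen-bond donor that enters with hydroxy matters remains open. A methoxy group or an amine at this place would bear on that question.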